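The source may hold more compounds than are shown below. What is called first, only, known or untested is meant among the compounds shown, and "the series" means these compounds.

Measured compounds in a functional assay on DU-145 cells (Homo sapiens) for cytotoxicity, read by CCK-8 assay and cell counting, with a stated time of 2 days; on this read-out higher numbers stand for weaker inhibition and lower numbers for stronger inhibition:
compound 1 `Oc1ccc(-c2cc(-c3cccnc3)nc(-c3ccccc3Cl)c2)cc1` — "not determined" (no result reported)
compound 2 `Oc1ccc(-c2cc(-c3cccs3)nc(-c3ccccc3Cl)c2)cc1` — 4190 nM
compound 3 `Oc1ccc(-c2cc(-c3ccco3)nc(-c3ccccc3Cl)c2)cc1` — 5300 nM

Compound 1 stands without a number in this assay; it differs from compound 2 and compound 3 only in the group that sits beside the 2-chlorophenyl group, where it carries pyridin-3-yl. For the measured compounds named here, compound 2 and compound 3 lie close together, and the one measured step, a 1.3-fold higher number from compound 2 to compound 3 (0.10 log units; within the scatter), sets no order between them.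

Compound 4 `Oc1ccc(-c2cc(-c3cccnc3)nc(-c3cccc(Cl)c3)c2)cc1` is the next compound. Its change from compound 1 is 3-chlorophenyl in place of 2-chlorophenyl on an aromatic carbon. Going by the values given here, no measured step bears on this change: the only step in hand exchanges the group on the other side of the shared core and is itself within the scatter, and compound 1 offers no number to start from. On these data alone, what remains is the level of compound 2 and compound 3, which both carry the 2-chlorophenyl group with a different partner ring; the 3-chlorophenyl group and the pyridin-3-yl group are untested here. The expectation for compound 4 therefore rests on that level alone, with a wide range to cover the two unknowns, and no direction is predicted beyond the scatter.

Compound 4 is estimated at 5000 nM in this assay, in the range 1500 nM to 16000 nM.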

Compound 4, half-maximal inhibitory concentration: 22900 nM
Beside the measured number, compound 4's estimate is 4.6-fold (0.66 log units) below it; the measured number lies above the stated range.
By their numbers in this assay, from the lowest: compounds 2 and 3 (each within the scatter of the next); then compound 4.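

Compound 1 and compound 4 differ in one place, but compound 1 has no single number in this assay, so no step can be read between them. No evidence on hand bears on the result of compound 4. The compounds shown leave open how 3-chlorophenyl compares with 2-chlorophenyl, and how pyridin-3-yl compares with thiophen-2-yl or furan-2-yl.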